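This account rests on a few compounds, and the source may have more. Where it says the series, first, only, none or still open, it means among the compounds named here.

Compound 1 `COc1ccc(NC(=O)C2CCCNC2)cc1`: 983000 nM
Compound 2 `O=C(Nc1ccc(OCc2ccc(F)cc2)cc1)C1CCCNC1`: 116000 nM

In a functional assay on a cell-free system (Platelet, plasma, Homo sapiens) for inhibition (on this read-out higher numbers stand for weaker inhibition and lower numbers for stronger inhibition), compound 2 has the lower of the two numbers, at 116000 nM. Compound 3 `O=C(Nc1ccc(OCc2ccc(F)cc2)cc1)C1CCNCC1` has the same atoms joined differently: piperidin-4-yl in place of piperidin-3-yl on a carbonyl carbon. Among the compounds with values here, the only measured step, an 8.5-fold lower number from compound 1 to compound 2 (0.93 log units; beyond the scatter), lies at another place in the molecule, so it gives neither size nor direction for this change. In this assay no step beyond the scatter is therefore expected: a 1.1-fold higher number from compound 2 to compound 3 (0.05 log units; within the scatter). For compound 3 the estimate is 130000 nM, with an expected range of 45000 nM to 400000 nM.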

Compound 3, half-maximal inhibitory concentration: 121000 nM
Beside the measured number, compound 3's estimate is 1.1-fold (0.03 log units) above it; the measured number falls inside the stated range.
By their numbers in this assay, from the lowest: compounds 2 and 3 (each within the scatter of the next); then compound 1.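

In this assay, piperidin-4-yl in place of piperidin-3-yl on a carbonyl carbon gives a 1.0-fold higher number from compound 2 to compound 3 (0.02 log units; within the scatter). With the rest of compound 2 held fixed, the two attachments of the ring therefore read alike, which the earlier step, at another place in the molecule, could not show. No measured evidence bears on this result.

Open, going by these compounds, is whether other groups on the carbonyl carbon, such as pyrrolidin-3-yl or an open-chain primary amine, would read the same. Also open, on these data alone, is whether this equivalence holds with the smaller methoxy end of compound 1.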